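The source may hold more compounds than are shown below. What is called first, only, known or untested is meant among the compounds shown, and "the series" means these compounds.

Working notes on the series.

Of the compounds shown here, three have been measured in a functional assay on HCT-116 cells (Homo sapiens) for cytotoxicity, read by crystal violet staining, with a stated time of 7 days; on this read-out higher numbers stand for weaker inhibition and lower numbers for stronger inhibition. Compound 1 `COc1ccc2c(c1)C=C(/C=C/C(=O)c1ccccc1OC)CO2` gives 1040 nM in this assay. Compound 2 `COc1ccc2c(c1)C=C(C(=O)/C=C/c1ccccc1OC)CO2` gives 1620 nM, the second highest of the three numbers; its nearest neighbour is compound 1, and the gap between the two lies within the usual scatter, so no order between compound 1 and compound 2 is claimed. Compound 3 `COc1ccc2c(c1)C=C(/C=C/C(=O)C1=Cc3cc(OC)ccc3OC1)CO2` gives 12900 nM, the highest number of the set and the furthest from compound 2, with a gap that lies beyond the scatter; compound 3 is thus the weakest inhibitor among those measured so far.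

Compound 4 `COc1ccc2c(c1)C=C(C(=O)/C=C/c1ccc(OC)cc1OC)CO2` has not yet been measured in this assay. Against compound 2 it shows one change: methoxy in place of hydrogen on an aromatic carbon. No measured pair in the set isolates a change of this kind, so nothing in the numbers shown speaks to its size or direction; the two compounds that carry a methoxy-substituted aryl ring on the enone, compound 1 and compound 2, sit close together, which gives no further guidance.

The expectation is therefore a step from compound 2 to compound 4 of a 1.2-fold lower number from compound 2 to compound 4 (0.06 log units; within the scatter), not beyond the scatter in either direction. Compound 4 is accordingly estimated at 1400 nM in this assay, within a range of 500 nM to 4000 nM.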

Compound 4, half-maximal inhibitory concentration: 3970 nM
The estimate for compound 4 lay 2.8-fold (0.45 log units) below the measured number; the measured number falls inside the stated range.
By their numbers in this assay, from the lowest: compounds 1 and 2 (each within the scatter of the next); then compound 4; then compound 3.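

In this assay, among these compounds, methoxy in place of hydrogen on an aromatic carbon gives a 2.5-fold higher number from compound 2 to compound 4 (0.39 log units; beyond the scatter), the first step that isolates a single change. The step is modest but beyond the scatter, and it runs towards weaker inhibition: at this position, meta to a methoxy group and para to a large group, the added methoxy comes with a cost rather than a gain or a neutral result. No measurement shown bears on why the number rises with this change.

Going by these compounds, with a single substituent at a single position, it remains open whether this step belongs to methoxy specifically or would follow from other groups on the same carbon, such as fluorine, hydroxyl or an amine, any of which would help to separate the two readings. On these data alone, it also remains open whether the same methoxy on the aryl ring of compound 1, which carries the enone the other way round, would give a step of similar size and direction.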